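Swapping the aryl group on a shared core

The compounds below may be only part of what the source reports. "The series", "measured", "known", "first", "only" and "open" are said of these compounds alone.

Compound 2 `Cc1cc(Br)ccc1Nc1c(-c2ccc3[nH]nc(C)c3c2)nc2cnc(N3CCN(C)CC3)cn12` gives 59.4% in a functional assay on MV4-11 cells (Homo sapiens) for inhibition, with a stated time of 120 h, tested at 10 uM (a lower number here means less inhibition, a higher number more inhibition at the concentration tested (going by the name of the read-out)), the lower of the two numbers recorded, while compound 1 `Cc1n[nH]c2ccc(-c3nc4cnc(N5CCN(C)CC5)cn4c3Nc3ccc(Br)cc3)cc12` gives 83%. Going by the values given here, the only measured step, a number 23.6 percentage points lower from compound 1 to compound 2 (beyond the scatter), is the one that bears on compound 3 `Cc1n[nH]c2ccc(-c3nc4cnc(N5CCN(C)CC5)cn4c3Nc3ccc(F)c(Cl)c3)cc12`, since the change to compound 3 is 3-chloro-4-fluorophenyl in place of 4-bromo-2-methylphenyl on a nitrogen on an aromatic ring and thereby removes that methyl while also exchanging the halogen. The methyl removal suggests a recovery, but nothing measured tells how the halogen swap acts, so compound 3 is expected to rise by a number 15.6 percentage points higher from compound 2 to compound 3 (beyond the scatter), with an estimated 75%, between 50% and 92%.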

Compound 3, a percentage reported as inhibition, at one concentration (the size of the read-out at that concentration, not a potency): 84.1%
Beside the measured number, compound 3's estimate is 9.1 percentage points below it; the range from low to high includes it.
By their numbers in this assay, from the lowest: compound 2; then compounds 1 and 3 (each within the scatter of the next).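

In this assay the exchange on the nitrogen gives a number 24.7 percentage points higher from compound 2 to compound 3 (beyond the scatter) and the exchange against the unmethylated compound gives a number 1.1 percentage points higher from compound 1 to compound 3 (within the scatter). The 4-bromophenyl and 3-chloro-4-fluorophenyl groups thus read alike at this position, so this place accepts more than one halogen pattern, and the low number of compound 2 is not shared by either. Nothing measured here explains these numbers. Going by these compounds, it remains open whether a phenyl bearing an amine or a carboxylic acid would hold this level, and whether a methyl on the 3-chloro-4-fluorophenyl ring would bring a similar drop.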